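Swapping a Pyrazole Group for an Indole Group

The compounds below may be only part of what the source reports. "The series", "measured", "known", "first", "only" and "open" are said of these compounds alone.

In an ADME assay on BaF3 cells (Mus musculus) for cytotoxicity (on this read-out higher numbers stand for an effect only at larger amounts of compound and lower numbers for an effect already at smaller amounts), the compounds measured so far give these values:
- Compound 1 (`CN1CCN(C(=O)c2cc3c(Nc4ccc(OC(F)(F)F)cc4)ncnc3s2)CC1`) gives 2690 nM
- Compound 2 (`CC(C)Cn1cc(-c2cc(Nc3ccc(OC(F)(F)F)cc3)ncn2)cn1`) gives > 10000 nM (a limit of the assay, not a number)

Compound 2 has no exact number, and where it stands is described as the limit of > 10000 nM in this assay, at which 1 of the 2 values shown sits (only a limit). For the measured compounds named here, compound 1 is the one compound here with an exact number (2690 nM), so an effect within the measured range does occur in this small set. Going by the values given here, no two measured compounds differ in one place only, and no measured step is available as a guide.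

Compound 3 (`FC(F)(F)Oc1ccc(Nc2cc(-c3cccc4[nH]ccc34)ncn2)cc1`) keeps the rest of compound 2 but carries 1H-indol-4-yl in place of 1-isobutyl-1H-pyrazol-4-yl on an aromatic carbon. A moderate shift toward lower numbers is expected, although a reading at the limit remains quite possible. The expected size of the change is an at least 1.6-fold lower number from compound 2 to compound 3 (0.22 log units; that floor lies within the scatter) (an estimate only). Compound 3 is estimated at 6000 nM (expected range 2000 nM to 10000 nM).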

Compound 3, half-maximal effective concentration: 3790 nM
Beside the measured number, compound 3's estimate is 1.6-fold (0.20 log units) above it; the range from low to high includes it.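

For the compounds shown here, for the first time, a single change can be read in this assay: putting 1H-indol-4-yl in place of 1-isobutyl-1H-pyrazol-4-yl on this aromatic carbon gives an at least 2.6-fold lower number from compound 2 to compound 3 (0.42 log units; beyond the scatter), so the group at this one position is enough to bring the read-out into the measured range. Compound 2 gives > 10000 nM, which is a limit of the assay and not a number. The step is therefore only a floor, and its full size stays unknown because compound 2 sits at that limit: the limit of > 10000 nM in this assay, at which 1 of the 3 values shown sits.

Which part of the swap matters remains open, since the two groups have the same number of heavy atoms but differ in their rings and in their hydrogen-bond donors and acceptors, and one pair of compounds cannot separate these differences. Also open, as far as these compounds go, is how a simple amine, a carboxylic acid or a longer alkyl chain at this position would read in this assay, and whether the same swap would have a similar effect on the core of compound 1.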